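Replacing a benzyl with isopropyl on the sulfonyl carbamate

The source may hold more compounds than are shown below. What is called first, only, known or untested is meant among the compounds shown, and "the series" means these compounds.

Measured compounds:
Compound 1 `CCCc1nc(CC)c(C(=O)OCc2ccccc2C(=O)c2ccccc2)n1Cc1ccc(-c2ccccc2S(=O)(=O)NC(=O)OCCc2ccccc2)cc1F`: 0.69 nM
Compound 2 `CCCc1nc(CC)c(C(=O)OCc2ccccc2OCCC(C)C)n1Cc1ccc(-c2ccccc2S(=O)(=O)NC(=O)OCCC(C)C)cc1F`: 10 nM

Both values come from an assay on isolated protein for binding affinity to Type-2 angiotensin II receptor (Homo sapiens); on this read-out higher numbers stand for weaker inhibition and lower numbers for stronger inhibition. Compound 1 holds the lowest of the two numbers; compound 2, the nearest, sits at a higher number than compound 1, and that gap lies beyond the scatter. For the measured compounds named here, the two compounds differ in more than one place, so no single step between them can be read off.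

Compound 3 `CCCc1nc(CC)c(C(=O)OCc2ccccc2C(=O)c2ccccc2)n1Cc1ccc(-c2ccccc2S(=O)(=O)NC(=O)OCC(C)C)cc1F` has not yet been measured in this assay. It differs from compound 1 in one place: isopropyl in place of benzyl on a saturated chain carbon bound to an oxygen next to a carbonyl group. The chain is thus shortened and the ring removed at that end, while the ester side of compound 1 is kept. Going by the values given here, as no measured pair shows this change alone, the size of the step is uncertain; a modest move toward a higher number, not beyond the scatter, is expected. Compound 3 is expected to give 1.8 nM, within a range from 0.5 nM to 7 nM. That estimate means an expected step of a 2.6-fold higher number from compound 1 to compound 3 (0.42 log units; beyond the scatter).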

Compound 3, half-maximal inhibitory concentration: 1 nM
For compound 3 the middle estimate is 1.8-fold (0.26 log units) above the measured one; the measured number falls inside the stated range.
By their numbers in this assay, from the lowest: compounds 1 and 3 (each within the scatter of the next); then compound 2.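

In this assay, the step for isopropyl in place of benzyl is a 1.4-fold higher number from compound 1 to compound 3 (0.16 log units; within the scatter), so the two compounds cannot be told apart at this position. With the ester side of compound 1 kept, the aromatic ring at this end of the sulfonyl carbamate is therefore not needed to retain a number of this size, and a small branched group without a ring serves as well in this assay. Nothing available accounts for this result.

The compounds shown leave open whether this position would accept a group other than a plain hydrocarbon, such as an amine or a carboxylic acid, or a longer chain. From the compounds shown here alone, it also remains open whether the same exchange would read alike with the ester side of compound 2.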